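Thiophene for Pyridine on a Shared Core: Compound 4

The compounds below may be only part of what the source reports. "The series", "measured", "known", "first", "only" and "open" are said of these compounds alone.

Compound 1 `Clc1cccc(Nc2ncnc3ccc(NCc4cccc(Br)n4)cc23)c1`: 3870 nM
Compound 2 `CCCCNc1ccc2ncnc(Nc3cccc(Cl)c3)c2c1`: 7850 nM
Compound 3 `O=C(/C=C/c1cccnc1)Nc1ccc2ncnc(Nc3cccc(Cl)c3)c2c1`: 9120 nM

Of the compounds shown here, three built on one shared core have been tested in a functional assay on HepG2 cells (Homo sapiens) for antiproliferative activity, read by MTT assay, with a stated time of 48 h; a lower number here means a stronger inhibitor, a higher number a weaker inhibitor. Compound 3 gives the highest of the three numbers, but its nearest neighbour, compound 2, lies within the usual scatter of it, so no order between compound 3 and compound 2 can be read. Compound 1 stands furthest away, with a number lower than that of compound 3 by more than the scatter.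

Compound 4 `O=C(/C=C/c1cccs1)Nc1ccc2ncnc(Nc3cccc(Cl)c3)c2c1` is the next compound, and it differs from compound 3 in one place: thiophen-2-yl in place of pyridin-3-yl on a double-bonded chain carbon bound to a double-bonded chain carbon.

Going by the values given here, only one measured step exists, a 2.0-fold higher number from compound 1 to compound 2 (0.31 log units; beyond the scatter), and it concerns a different part of the molecule, where an aryl group gave way to an alkyl chain. It does not speak directly to an exchange of one aromatic ring for another on the ethenyl arm of the amide. The evidence therefore supports no step beyond the scatter in this assay, in either direction, and the expected step is a 1.0-fold lower number from compound 3 to compound 4 (0.01 log units; within the scatter).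

Compound 4 is estimated at 9000 nM in this assay, within a range of 4000 nM to 20000 nM.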

Compound 4, half-maximal inhibitory concentration: 10400 nM
For compound 4 the middle estimate is 1.2-fold (0.06 log units) below the measured one; measured number inside the range.
By their numbers in this assay, from the lowest: compound 1; then compounds 2, 3 and 4 (each within the scatter of the next).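

In this assay, going by these compounds alone, thiophen-2-yl in place of pyridin-3-yl on a double-bonded chain carbon bound to a double-bonded chain carbon gives a 1.1-fold higher number from compound 3 to compound 4 (0.06 log units; within the scatter) and so gives the first reading at this position: a five-membered aromatic ring with sulfur as its hetero atom and a six-membered aromatic ring with nitrogen as its hetero atom cannot be told apart here. The same holds one step further out, where (2-(thiophen-2-yl)ethenyl)carbonyl in place of butyl on a nitrogen on an aromatic ring gives a 1.3-fold higher number from compound 2 to compound 4 (0.12 log units; within the scatter) and no order can be read, whereas the same group in place of (6-bromopyridin-2-yl)methyl gives a 2.7-fold higher number from compound 1 to compound 4 (0.43 log units; beyond the scatter) and this modest step leaves compound 1 alone apart from the other three. Nothing in the data shown accounts for any of these steps.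

As far as these compounds go, what a plain phenyl ring or a furan-2-yl ring would give on the ethenyl arm remains open. So does the outcome of a saturated ethyl link in place of the ethenyl link, or of a dimethylamino group on the end of that arm.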